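The source may hold more compounds than are shown below. What is called first, only, known or untested is meant among the compounds shown, and "the series" means these compounds.

Working notes on the series in a functional assay on the whole organism (strain Wister albino) for inhibition, with Rattus norvegicus as the target, read by paw edema, with stated times of 1 h and 2 h, at a dose of 50 mg/kg by the intraperitoneal route; on this read-out higher numbers stand for more inhibition at the one dose given (going by the name of the read-out) and lower numbers for less inhibition. Compound 1 `Cc1ccc([C@@H]2CN(C)[C@]3(C(=O)Nc4ccccc43)[C@]23Cc2ccccc2C3=O)cc1` gives 23.8%. Compound 2 `CN1C[C@@H](c2ccccc2)[C@@]2(Cc3ccccc3C2=O)[C@@]12C(=O)Nc1ccccc12` gives 40%. For the measured compounds named here, the one step between them, a number 16.2 percentage points higher from compound 1 to compound 2 (beyond the scatter), is the only measured change so far. Going by the values given here, compound 2 therefore stands highest of the two numbers in this assay, with compound 1 as its only neighbour, and that gap is beyond the scatter.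

Compound 3 `CN1C[C@@H](c2ccc(F)cc2)[C@@]2(Cc3ccccc3C2=O)[C@@]12C(=O)Nc1ccccc12` differs from compound 2 by fluoro in place of hydrogen on an aromatic carbon. The step from compound 1 to compound 2 bears on it, since it alters the same aromatic carbon of the same phenyl, and there the entry of methyl brought the number down. No fluoro-for-hydrogen change has been measured in the series. The expectation for compound 3 is a modest downward step, a number 6 percentage points lower from compound 2 to compound 3 (within the scatter), likely within the scatter. Compound 3 is estimated at 34%, with a range from 20% to 48%.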

Compound 3, a percentage reported as inhibition, in the whole organism at one dose (the size of the read-out at that dose, not a potency): 21.2%
Compound 3: middle estimate off by 12.8 percentage points, on the high side; the measured number falls inside the stated range.
By their numbers in this assay, from the lowest: compounds 3 and 1 (each within the scatter of the next); then compound 2.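

In this assay the fluoro-for-hydrogen change on this aromatic carbon, para to a large group, gives a number 18.8 percentage points lower from compound 2 to compound 3 (beyond the scatter) and so shows that a single fluorine atom here is enough to produce a drop of about the same size as methyl. The direct comparison of the two substituents gives a number 2.6 percentage points lower from compound 1 to compound 3 (within the scatter), which leaves methyl and fluoro not separable at this position, while compound 2, with hydrogen, stands beyond the scatter from both. No measurement bears on why either substituent lowers the number.

Going by these compounds, whether the hydrogen of compound 2 is preferred over substituents generally remains open, as only two have been seen here and a methoxy group, a chlorine atom or an amine on this carbon could behave differently. Also open, on these data alone, is whether fluoro has the same effect on another carbon of this phenyl ring.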